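A few compounds are considered here, and "the series" means these few. Any claim that something is new, unique, unknown or untested is made for them only; others in the source may bear on it.

Values so far in an ADME assay on HepG2 2.2.15 cells (Homo sapiens) for cytotoxicity; a lower number here means that less compound is tolerated, a higher number that more compound is tolerated:
- compound 1 `CCCCC(=O)OCCc1c(-c2ccccc2Cl)c2cc(Cl)ccc2[nH]c1=O`: 200000 nM
- compound 2 `O=C(OCCc1c(-c2ccccc2Cl)c2cc(Cl)ccc2[nH]c1=O)C1CCCC1`: 46000 nM

Compound 2 holds the lower of the two numbers. The next compound to read out is compound 3 `O=C(CCC1CCCCC1)OCCc1c(-c2ccccc2Cl)c2cc(Cl)ccc2[nH]c1=O`, which has 2-cyclohexylethyl in place of cyclopentyl on a carbonyl carbon.

Among the compounds with values here, only one measured step bears on this change: a 4.3-fold lower number from compound 1 to compound 2 (0.64 log units; beyond the scatter), with cyclopentyl in place of butyl at the same place. That single modest step involves a different pair of groups, so it is weak guidance. On that basis, a further modest step to a lower number is expected in this assay, not a large one. The estimated step is a 2.3-fold lower number from compound 2 to compound 3 (0.36 log units; beyond the scatter). The estimate for compound 3 is 20000 nM, with an expected range of 6000 nM to 70000 nM.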

Compound 3, half-maximal cytotoxic concentration: 160000 nM
Compound 3: the middle estimate sits 8.0-fold (0.90 log units) below what was measured; measured number above the stated range.
By their numbers in this assay, from the lowest: compound 2; then compounds 3 and 1 (each within the scatter of the next).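

In this assay the downward move does not continue from cyclopentyl to the longer group on this carbonyl carbon (a 3.5-fold higher number from compound 2 to compound 3 (0.54 log units; beyond the scatter)), so size alone does not order the three groups tested here. Cyclohexyl in place of ethyl on a saturated chain carbon, two bonds along the chain from a carbonyl carbon, gives no change that can be read (a 1.3-fold lower number from compound 1 to compound 3 (0.10 log units; within the scatter)), and among these three compounds only compound 2, with its ring directly on the carbonyl carbon, stands apart from the other two. No measurement at hand accounts for these differences.

Going by these compounds, whether the lower number belongs to cyclopentyl alone or to any ring directly on the carbonyl carbon remains open, and cyclohexyl or phenyl at that place would address it. Also open, on these data alone, is how an amine or a carboxylic acid at the end of the chain would read in this assay.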